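Hydrazone aryl swap on the shared core

The compounds below may be only part of what the source reports. "The series", "measured", "known", "first", "only" and "open" are said of these compounds alone.

Measured so far:
compound 1 `Cn1c(=O)c(=O)n(C2CCCC2)c2nc(N/N=C/c3cccc([N+](=O)[O-])c3)ncc21` — 20300 nM
compound 2 `Cn1c(=O)c(=O)n(C2CCCC2)c2nc(N/N=C/c3cc([N+](=O)[O-])ccc3Cl)ncc21` — 9260 nM

In a functional assay on PC-3 cells (Homo sapiens) for antiproliferative activity, read by MTT assay (a lower number here means a stronger inhibitor, a higher number a weaker inhibitor), compound 1 gives 20300 nM and compound 2 gives 9260 nM. Within the data shown here, compound 2 stands at the lower of the two numbers; the only measured step is a 2.2-fold lower number from compound 1 to compound 2 (0.34 log units; beyond the scatter), a modest change, beyond the scatter.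

Compound 3 `CSc1ccc(/C=N/Nc2ncc3c(n2)n(C2CCCC2)c(=O)c(=O)n3C)cc1` is the next case. Its change from compound 2 is 4-(methylsulfanyl)phenyl in place of 2-chloro-5-nitrophenyl on a carbon with a double bond to nitrogen. Among the measured compounds shown here, no measured step covers this exchange directly: the one step known, a 2.2-fold lower number from compound 1 to compound 2 (0.34 log units; beyond the scatter), concerns only the chloro, and that chloro is among what leaves here, so if anything a drift back toward the number of compound 1 is plausible. The size cannot be read from the data, and a step within the scatter is as likely as a modest one.

Compound 3 is therefore expected near 15000 nM, with a range of 4000 nM to 60000 nM. The expected step is a 1.6-fold higher number from compound 2 to compound 3 (0.21 log units; within the scatter).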

Compound 3, half-maximal inhibitory concentration: 21000 nM
The estimate for compound 3 lay 1.4-fold (0.15 log units) below the measured number, and the stated range covers the measured number.
By their numbers in this assay, from the lowest: compound 2; then compounds 1 and 3 (each within the scatter of the next).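

In this assay, 4-(methylsulfanyl)phenyl in place of 2-chloro-5-nitrophenyl gives a 2.3-fold higher number from compound 2 to compound 3 (0.36 log units; beyond the scatter) and 4-(methylsulfanyl)phenyl in place of 3-nitrophenyl gives a 1.0-fold higher number from compound 1 to compound 3 (0.01 log units; within the scatter) on the same carbon with a double bond to nitrogen. A phenyl ring with no nitro group therefore reads level with the 3-nitrophenyl compound, so across these three compounds the nitro group alone does not set the number, and only the 2-chloro-5-nitrophenyl compound stands apart, by a modest margin. No measurement available here accounts for this.

The compounds shown leave open how a phenyl ring carrying an amine or a carboxylic acid would read at this position. They also leave open whether chloro would give a similar step on 4-(methylsulfanyl)phenyl, where no nitro group is present.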